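Extending a Side Chain by One Carbon on Two Cores

The source may report more compounds than this note shows. Statements on the series, on what has been measured and on what is new or still open speak of the compounds shown alone.

Compound 1 `CN(C)C(=O)c1cc2cnc(Nc3ccc(C(=O)NCCCN=C=S)cc3O)nc2n1C1CCCC1` and compound 2 `CN(C)C(=O)c1cc2cnc(Nc3ccc(C(=O)NCCCCN=C=S)cc3O)nc2n1C1CCCC1` share one core and differ by a single change, (a group of 4 heavy atoms (2 carbon, 1 nitrogen, 1 sulfur; no ring) in place of a group of 3 heavy atoms (1 carbon, 1 nitrogen, 1 sulfur; no ring), on a saturated chain carbon, three bonds along the chain from an amide-type nitrogen). In a functional assay on NCI-H1299 cells (Homo sapiens) for inhibition, read by CCK-8 assay, with a stated time of 72 h, tested at 1 uM (a higher number here means a stronger effect of the compound at the concentration tested, a lower number a weaker effect), compound 1 gives 10.3% and compound 2 gives 10.7%, so a number 0.4 percentage points higher from compound 1 to compound 2 (within the scatter). Compound 3 `CN(C)C(=O)c1cc2cnc(Nc3ccc(NC(=O)CCCCN=C=S)cc3)nc2n1C1CCCC1` is built on a different core; the difference between the two cores is not broken down here. In this assay compound 3 gives 58.6%. Compound 4 `CN(C)C(=O)c1cc2cnc(Nc3ccc(NC(=O)CCCCCN=C=S)cc3)nc2n1C1CCCC1` has not yet been measured. It differs from compound 3 by the same kind of change, (a group of 4 heavy atoms (2 carbon, 1 nitrogen, 1 sulfur; no ring) in place of a group of 3 heavy atoms (1 carbon, 1 nitrogen, 1 sulfur; no ring), on a saturated chain carbon, four bonds along the chain from a carbonyl carbon), although here the place is four bonds along the chain from a carbonyl carbon rather than three bonds along the chain from an amide-type nitrogen. Because a number 0.4 percentage points higher from compound 1 to compound 2 (within the scatter), the step of a number 0.6 percentage points lower from compound 3 to compound 4 (within the scatter) is expected to be similarly small. Compound 4 is therefore estimated at 58%, with a likely range from 42% to 72%.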

Compound 4, a percentage reported as inhibition, at one concentration (the size of the read-out at that concentration, not a potency): 34.3%
Compound 4: middle estimate off by 23.7 percentage points, on the high side; measured number below the stated range.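

In this assay, lengthening the chain by one carbon on the core of compound 3 gives a number 24.3 percentage points lower from compound 3 to compound 4 (beyond the scatter), so this step cannot simply be carried over from the core of compound 1. The same change behaves differently on the two cores: the same change on two cores in this assay, a number 0.4 percentage points higher (within the scatter) from compound 1 to compound 2 and a number 24.3 percentage points lower (beyond the scatter) from compound 3 to compound 4, 24.7 percentage points apart, beyond the scatter of two such steps

Among these compounds, this rests on only two pairs of compounds, each read at a single concentration, and the cores differ in more than one place, so it does not show which part of the core matters or why.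

Going by these compounds, a still longer chain on either core remains open. So does whether an amine in place of the group holding the nitrogen and sulfur would keep any of the effect.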